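This account rests on a few compounds, and the source may have more. Where it says the series, first, only, none or still open, it means among the compounds named here.

Measured so far in a functional assay on the whole organism (Hindlimb, strain albino) with Mus musculus as the target, in the maximal electroshock model, with a stated time of 0.5 h; a higher number here means that more compound is needed for the effect, a lower number that less compound is needed:
- compound 1 `Cc1ccc2nc(NC(=O)/C=C/c3ccc(O)cc3)sc2c1`: 271 umol/kg
- compound 2 `O=C(/C=C/c1ccc(O)cc1)Nc1nc2ccccc2s1`: 517 umol/kg
- compound 3 `O=C(/C=C/c1ccc(O)cc1)Nc1nc2ccc([N+](=O)[O-])cc2s1`: 382 umol/kg

Compound 2 lies within the scatter of both other compounds, as shown by a 1.9-fold higher number from compound 1 to compound 2 (0.28 log units; within the scatter) and a 1.4-fold lower number from compound 2 to compound 3 (0.13 log units; within the scatter). Compound 4 `O=C(/C=C/c1ccccc1)Nc1nc2ccccc2s1` is the next one to be read against it. The change is hydrogen in place of hydroxy on an aromatic carbon, or 4-hydroxyphenyl to phenyl.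

Among the compounds with values here, no measured step removes the hydroxy, so the series offers no direct precedent. The three measured steps, including a 1.4-fold higher number from compound 1 to compound 3 (0.15 log units; within the scatter), all exchange another group and keep the hydroxy in place. They bear on this change only indirectly, showing that single substitutions in these compounds have so far stayed within the scatter. On that limited basis, no step beyond the scatter is expected in this assay, and no direction can be read from the data.

The estimated step is a 1.1-fold lower number from compound 2 to compound 4 (0.06 log units; within the scatter).

For compound 4 the expected value is 450 umol/kg, with an estimated range from 170 umol/kg to 1200 umol/kg.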

Compound 4, dose for half-maximal effect: 646 umol/kg
Estimate against measurement, compound 4: 1.4-fold (0.16 log units) below, and the stated range covers the measured number.
By their numbers in this assay, from the lowest: compounds 1, 3, 2 and 4 (each within the scatter of the next, the first and the last beyond it).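

Taking away the hydroxy (4-hydroxyphenyl to phenyl) gives in this assay a 1.2-fold higher number from compound 2 to compound 4 (0.10 log units; within the scatter) and so stays within the scatter, the first reading at this position itself. Within the data shown here, on the core of compound 2, the hydroxy is therefore not needed for activity in this model at the level these numbers can resolve, and the earlier steps, which all kept it in place, could not show this. No measured data bear on why this step is small.

As far as these compounds go, this rests on one pair, so it remains open whether the phenyl change would read the same with the methyl of compound 1 or the nitro of compound 3 on the core. Also open, from the compounds shown here alone, is whether a methoxy, an amine or a carboxylic acid at this position would stay within the scatter or move the number beyond it.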